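Reverse of the cyclopropyl step in the series

The compounds below may be only part of what the source reports. "The series", "measured", "known", "first", "only" and "open" are said of these compounds alone.

Compound 1 `Cc1cc(NC(=O)Cn2nnc(-c3ccc(F)c(F)c3)n2)n(C2CCCCC2)n1` gives 116 nM in an assay on HEK293 cells for activation of Kir3.1/Kir3.2 (Homo sapiens), read by thallium flux (on this read-out lower numbers stand for an effect already at smaller amounts and higher numbers for an effect only at larger amounts of compound), and compound 2 `Cc1ccc(-c2nnn(CC(=O)Nc3cc(C)nn3C3CCCCC3)n2)cc1` gives 111 nM; the change between them is a 1.0-fold lower number from compound 1 to compound 2 (0.02 log units; within the scatter). Compound 3 `Cc1cc(NC(=O)Cn2nnc(C3CC3)n2)n(C2CCCCC2)n1` reaches only the limit of this assay, > 3000 nM, as recorded by the limit of > 3000 nM in this assay, at which 1 of the 3 values shown sits. The measured steps of an at least 25-fold higher number from compound 1 to compound 3 (1.41 log units; beyond the scatter) and an at least 27-fold higher number from compound 2 to compound 3 (1.43 log units; beyond the scatter) both show that cyclopropyl in place of an aryl group raises the number strongly. Compound 4 `Cc1cc(NC(=O)Cn2nnc(-c3ccc(Cl)c(C)c3)n2)n(C2CCCCC2)n1` runs the other way: 4-chloro-3-methylphenyl in place of cyclopropyl on an aromatic carbon. Both aryl steps bear on this change and were large in the same direction, so a large fall in the number is expected, an at least 25-fold lower number from compound 3 to compound 4 (1.39 log units; beyond the scatter). Compound 4 is therefore estimated to give 120 nM in this assay, with a range from 50 nM to 400 nM.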

Compound 4, half-maximal effective concentration: 712 nM
For compound 4 the middle estimate is 5.9-fold (0.77 log units) below the measured one; measured number outside the range, above it.
By their numbers in this assay, from the lowest: compounds 2 and 1 (each within the scatter of the next); then compound 4. At a limit, above all of these: compound 3.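

In this assay, aryl groups on this aromatic carbon no longer read as interchangeable: 4-chloro-3-methylphenyl gives a 6.4-fold higher number from compound 2 to compound 4 (0.81 log units; beyond the scatter) and a 6.1-fold higher number from compound 1 to compound 4 (0.79 log units; beyond the scatter), whereas 4-methylphenyl and 3,4-difluorophenyl had stayed within the scatter of each other. It still improves on cyclopropyl, with an at least 4.2-fold lower number from compound 3 to compound 4 (0.62 log units; beyond the scatter), so the gain from an aryl group varies with what the ring carries. That step is only a bound, as compound 3 stands at a limit: the limit of > 3000 nM in this assay, at which 1 of the 4 values shown sits.

Open, from the compounds shown here alone, is whether 4-chlorophenyl or 3-methylphenyl alone would show the same rise in number. Also open, going by these compounds, is how a pyridyl ring or a cyclohexyl group would read on this carbon.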